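A few compounds are considered here, and "the series" means these few. Any claim that something is new, unique, unknown or untested is made for them only; others in the source may bear on it.

Three hydroxamic acids built on two cores have been tested in a functional assay on MCF7 cells (Homo sapiens) for inhibition, read by MTT assay, with a stated time of 72 h; a lower number here means a stronger inhibitor, a higher number a weaker inhibitor. Compound 1 `Nc1ncnc2c1c(-c1cnc3[nH]ccc3c1)nn2CCCCCCCCCC(=O)NO` and compound 2 `Nc1ncnc2c1c(-c1cnc3[nH]ccc3c1)nn2CCCCCCC(=O)NO` share one core and differ only in the chain; compound 3 `Nc1nc2cc(-c3nn(CCCCCC(=O)NO)c4ncnc(N)c34)ccc2o1` carries a second core, and how the two cores differ is not broken down here. In this assay compound 2 gives 19800 nM, compound 1 gives 23200 nM and compound 3 gives 12400 nM. All three numbers lie within the scatter of one another, so no order among them can be read. The change from compound 2 to compound 1 is 3-(hydroxycarbamoyl)propyl in place of hydroxycarbamoyl on a saturated chain carbon, six bonds along the chain from an aromatic nitrogen; it makes a step of a 1.2-fold higher number from compound 2 to compound 1 (0.07 log units; within the scatter).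

Compound 4 `Nc1nc2cc(-c3nn(CCCCCCCCC(=O)NO)c4ncnc(N)c34)ccc2o1` is not yet measured; it arises from compound 3 by 3-(hydroxycarbamoyl)propyl in place of hydroxycarbamoyl on a saturated chain carbon, five bonds along the chain from an aromatic nitrogen. This is the same kind of change as from compound 2 to compound 1, but not the same: in compound 1 the entering group sits six bonds along the chain from an aromatic nitrogen, in compound 4 five bonds along. For the measured compounds named here, on the first core the change left the number where it was within the scatter; on the core of compound 3 there is only one measured point, so the expectation rests on the single step of a 1.2-fold higher number from compound 2 to compound 1 (0.07 log units; within the scatter) and on the value of compound 3 12400 nM. Within the scatter, the expected step here is a 1.2-fold higher number from compound 3 to compound 4 (0.07 log units; within the scatter). Compound 4 is thus estimated at 14500 nM in this assay, with a range from 7000 nM to 30000 nM.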

Compound 4, half-maximal inhibitory concentration: 42100 nM
The estimate for compound 4 lay 2.9-fold (0.46 log units) below the measured number; measured number outside the range, above it.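

In this assay, putting 3-(hydroxycarbamoyl)propyl in place of hydroxycarbamoyl on the second core gives a 3.4-fold higher number from compound 3 to compound 4 (0.53 log units; beyond the scatter), so on this core the longer chain goes with a weaker number. The change therefore does not carry over from one core to the other with a single size, and the step from the first core would not have served as a transfer value here: the same change on two cores in this assay, a 1.2-fold higher number (0.07 log units; within the scatter) from compound 2 to compound 1 and a 3.4-fold higher number (0.53 log units; beyond the scatter) from compound 3 to compound 4, 2.9-fold (0.46 log units) apart, beyond the scatter of two such steps This shows a difference between two pairs only and does not assign it to the cores themselves, since the two pairs also differ in where the change falls, six bonds along the chain from an aromatic nitrogen on the first core and five bonds along on the second, and each core contributes one step.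

Still open, on these data alone, is whether chains of matched length on both cores would give steps of the same size, and whether a still longer chain on the core of compound 3 would continue the direction of this step. Also open, as far as these compounds go, is how either core would read in this assay with a carboxylic acid or an amine at the chain end in place of hydroxycarbamoyl.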